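A few compounds are considered here, and "the series" means these few. Any claim that something is new, unique, unknown or untested is made for them only; others in the source may bear on it.

Measured so far in a functional assay on PC-3 cells (Homo sapiens) for inhibition, read by sulforhodamine B assay, with a stated time of 48 h; a higher number here means a weaker inhibitor of growth, a lower number a stronger inhibitor of growth:

- compound 1 `Nc1cc(N)c2nc(-c3ccccc3)c(Oc3ccc(Cl)c(Cl)c3)nc2c1`: 14500 nM
- compound 2 `CCOC(=O)[C@H](CCC(=O)O)NC(=O)c1ccc(CNc2nc3cc(N)cc(N)c3nc2-c2ccccc2)cc1`: < 100000 nM (a limit of the assay, not a number)
- compound 3 `Nc1cc(N)c2nc(-c3ccccc3)c(NCc3ccc(Cl)c(Cl)c3)nc2c1`: 5130 nM

Compound 3 gives the lowest of the two numbers in this assay. Its nearest neighbour is compound 1, whose number is higher by a margin beyond the usual scatter. Compound 2 returns only a limit, as in the limit of < 100000 nM in this assay, at which 1 of the 3 values shown sits, and gives no number to set against the others.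

Compound 4 `COc1ccc(CNc2nc3cc(N)cc(N)c3nc2-c2ccccc2)cc1OC` has not been measured in this assay. It differs from compound 3 in one place: 3,4-dimethoxyphenyl in place of 3,4-dichlorophenyl on a saturated chain carbon bound to a nitrogen on an aromatic ring. Going by the values given here, no measured pair in this set carries the same change, so the size of the step rests on expectation alone. The step from compound 3 to compound 4 is expected to be upward, that is toward a weaker inhibitor of growth, by about a 2.3-fold higher number from compound 3 to compound 4 (0.37 log units; beyond the scatter), which lies beyond the scatter but leaves compound 4 well away from the assay limit. Compound 4 is therefore estimated at 12000 nM in this assay, with a range from 3500 nM to 45000 nM.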

Compound 4, concentration for total growth inhibition: 27500 nM
For compound 4 the middle estimate is 2.3-fold (0.36 log units) below the measured one; low and high end bracket the measured number.
By their numbers in this assay, from the lowest: compound 3; then compounds 1 and 4 (each within the scatter of the next).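

In this assay, the change from 3,4-dichlorophenyl to 3,4-dimethoxyphenyl gives a 5.4-fold higher number from compound 3 to compound 4 (0.73 log units; beyond the scatter) and so a weaker inhibitor of growth. Going by these compounds alone, this is the first single-place step, and it shows that the number responds to the group carried on a saturated chain carbon bound to a nitrogen on an aromatic ring, which the earlier compounds offered no pair to test. Nothing at hand accounts for the size or direction of this step.

From the compounds shown here alone, with only these two groups compared, it remains open how an unsubstituted phenyl, a single chlorine or methoxy on the phenyl, or a carboxylic acid would fall. One step also leaves open whether the same change would move the number in the same direction on the core of compound 1.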